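Swapping trifluoromethyl for methoxy on compound 2

This account rests on a few compounds, and the source may have more. Where it says the series, first, only, none or still open, it means among the compounds named here.

For the measured compounds named here, compound 2 (`O=C(Nc1ccc(NCc2ccc(C(F)(F)F)cc2)cc1Cl)c1cc(Cl)ccc1O`) is the only member of this small set with a number so far. In an ADME assay on A549 cells (Homo sapiens) for cytotoxicity, read by resazurin assay, with a stated time of 48 h (a higher number here means that more compound is tolerated, a lower number that less compound is tolerated), compound 2 gives 62700 nM and so stands alone, with no other value to rank it against. Compound 1 (`CC(=O)Nc1ccc(NC(=O)c2cc(Cl)ccc2O)c(Cl)c1`) has the shared core, but for compound 1 the entry reads "not determined" (no result reported) and offers no comparison.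

Compound 3 (`COc1ccc(CNc2ccc(NC(=O)c3cc(Cl)ccc3O)c(Cl)c2)cc1`) departs from compound 2 in a single place, with methoxy in place of trifluoromethyl on an aromatic carbon, para to a large group (methoxy in place of trifluoromethyl on an aromatic carbon). Going by the values given here, no step between measured compounds is available to size such a change in this assay, and the data give no precedent for its direction. The working expectation is therefore a shift no larger than the usual scatter, slightly upward if anything, resting only on compound 2 at 62700 nM and on the rest of the structure staying the same. The expected change is a 1.1-fold higher number from compound 2 to compound 3 (0.05 log units; within the scatter) as an estimate. Compound 3 is expected at 70000 nM with 30000 nM to 150000 nM as the estimated range.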

Compound 3, half-maximal cytotoxic concentration: 80700 nM
Compound 3: middle estimate off by 1.2-fold (0.06 log units), on the low side; the range from low to high includes it.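

In this assay, for the compounds shown here, putting methoxy in place of trifluoromethyl on the aromatic carbon gives a 1.3-fold higher number from compound 2 to compound 3 (0.11 log units; within the scatter), the first step that can be sized at this position. The 4-(trifluoromethyl)phenyl and 4-methoxyphenyl versions therefore cannot be told apart in this read-out, although the entering group is smaller by heavy atoms and brings a hydrogen-bond acceptor that the leaving group lacks. No measured property is available to bear on this result.

A single step within the scatter leaves open whether other groups on this aromatic carbon, such as an amine or a carboxylic acid, would also read alike in this assay, since the two groups compared here mark out only a small part of what could stand there. It also leaves open whether a longer chain in place of methoxy, or the same exchange made with another part of the structure altered, would keep the number within the scatter of these two compounds.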